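Relocating a Hydroxyl Group on a Shared Core

This account rests on a few compounds, and the source may have more. Where it says the series, first, only, none or still open, it means among the compounds named here.

Compound 3 `Oc1cccc(-c2cc(-c3ccccn3)cc(-c3ccccc3O)n2)c1` stands highest of the three measured compounds in a functional assay on DU-145 cells (Homo sapiens) for cytotoxicity, read by CCK-8 assay (on this read-out higher numbers stand for weaker inhibition and lower numbers for stronger inhibition), giving 17100 nM. Going by the values given here, compound 1 `Oc1cccc(-c2cc(-c3ccsc3)cc(-c3cccc(O)c3)n2)c1` gives 1310 nM in this assay, and compound 2 `Oc1cccc(-c2cc(-c3ccoc3)cc(-c3cccc(O)c3)n2)c1` gives 1650 nM; the single recorded step, a 1.3-fold higher number from compound 1 to compound 2 (0.10 log units; within the scatter), is small. Compound 4 `Oc1cccc(-c2cc(-c3ccccn3)cc(-c3cccc(O)c3)n2)c1` differs from compound 3 in one place: 3-hydroxyphenyl in place of 2-hydroxyphenyl on an aromatic carbon. Among the compounds with values here, no measured step moves a hydroxyl group, so none bears directly on this change. Compounds 1 and 2, which both carry two 3-hydroxyphenyl groups, sit far lower than compound 3, yet their third group also differs from that of compound 4, so the pull is uncertain. Compound 4 is expected to show a 5.7-fold lower number from compound 3 to compound 4 (0.76 log units; beyond the scatter), an estimated 3000 nM with a range from 900 nM to 10000 nM.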

Compound 4, half-maximal inhibitory concentration: 3610 nM
The estimate for compound 4 lay 1.2-fold (0.08 log units) below the measured number, within the range that was stated.
By their numbers in this assay, from the lowest: compounds 1 and 2 (each within the scatter of the next); then compound 4; then compound 3.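

In this assay, going by these compounds alone, 3-hydroxyphenyl in place of 2-hydroxyphenyl on the same aromatic carbon gives the first direct reading of this change (a 4.7-fold lower number from compound 3 to compound 4 (0.68 log units; beyond the scatter)). With 3-hydroxyphenyl held constant, pyridin-2-yl can also now be compared with the other two groups (a 2.2-fold higher number from compound 2 to compound 4 (0.34 log units; beyond the scatter)) and (a 2.8-fold higher number from compound 1 to compound 4 (0.44 log units; beyond the scatter)). No evidence is available to account for these differences.

Still open, as far as these compounds go, is how 4-hydroxyphenyl or 3-aminophenyl would read on this carbon. From the compounds shown here alone, it is also open whether moving the hydroxyl group would give a similar step with furan-3-yl or thiophen-3-yl in place of pyridin-2-yl.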